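Sulfanyl-linked heteroaryl replacements for the oxazolyloxy group of compound 1

The source may hold more compounds than are shown below. What is called first, only, known or untested is meant among the compounds shown, and "the series" means these compounds.

Measured so far:
compound 1 `COC(=O)c1cc(OCC(=O)[C@H](CC(=O)O)NC(=O)[C@@H](NC(=O)COc2cccc3ccccc23)C(C)C)no1` — 71000 nM
compound 2 `CC(C)[C@H](NC(=O)COc1cccc2ccccc12)C(=O)N[C@@H](CC(=O)O)C(=O)CSc1nc[nH]n1` — > 200000 nM (a limit of the assay)
compound 3 `CC(C)[C@H](NC(=O)COc1cccc2ccccc12)C(=O)N[C@@H](CC(=O)O)C(=O)CSc1nc2ccccc2s1` — > 200000 nM (a limit of the assay)

Three compounds share the core of compound 1. Among the compounds with values here, in a functional assay on Jurkat cells (Homo sapiens) for inhibition (on this read-out lower numbers stand for stronger inhibition and higher numbers for weaker inhibition), compound 1 gives 71000 nM, and this is the only real number in the set. Compound 2 is reported only as the limit > 200000 nM. Compound 3 also sits at the limit > 200000 nM. The two measured steps that change the group on the saturated chain carbon bound to a carbonyl carbon both run the same way: an at least 2.8-fold higher number from compound 1 to compound 2 (0.44 log units; beyond the scatter), and an at least 2.8-fold higher number from compound 1 to compound 3 (0.44 log units; beyond the scatter). Between the two limit compounds, a step that the two limits leave unreadable from compound 2 to compound 3. Both limits fall at the limit of > 200000 nM in this assay, at which 2 of the 3 values shown sit.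

Compound 4 `Cc1cc(C)nc(SCC(=O)[C@H](CC(=O)O)NC(=O)[C@@H](NC(=O)COc2cccc3ccccc23)C(C)C)n1` differs from compound 1 in the same position: (4,6-dimethylpyrimidin-2-yl)sulfanyl in place of (5-(methoxycarbonyl)-1,2-oxazol-3-yl)oxy on a saturated chain carbon bound to a carbonyl carbon. The two comparable steps from compound 1 each gave an at least modest weakening to the assay limit, so a weakening beyond the scatter is expected in this assay for compound 4 as well, most probably ending at the limit again. Compound 4 is therefore estimated at 200000 nM, with a range of 60000 nM to 600000 nM. The expected step is a 2.8-fold higher number from compound 1 to compound 4 (0.45 log units; beyond the scatter).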

Compound 4, half-maximal inhibitory concentration: > 200000 nM
Compound 4: a limit, no number (the forecaster's own chance of this, stated with the estimate: 65%); the middle value sits exactly at the limit.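

In this assay, the change to (4,6-dimethylpyrimidin-2-yl)sulfanyl on the saturated chain carbon bound to a carbonyl carbon gives an at least 2.8-fold higher number from compound 1 to compound 4 (0.44 log units; beyond the scatter). This extends the direction already seen with the 1H-1,2,4-triazol-3-yl and 1,3-benzothiazol-2-yl groups to a group with a six-membered aromatic ring, and none of the sulfanyl-linked compounds shown goes against it. The steps among compound 2, compound 3 and compound 4 cannot be read, so no order can be set among these three groups, and the series now rests mostly on an assay limit: the limit of > 200000 nM in this assay, at which 3 of the 4 values shown sit.

Each replacement shown changes the ring and the linking atom together, so the compounds shown do not separate the effect of the sulfur from that of the heteroaryl group; (5-(methoxycarbonyl)-1,2-oxazol-3-yl)sulfanyl or (4,6-dimethylpyrimidin-2-yl)oxy at this position would address that question directly. Also open, on these data alone, is whether the methoxycarbonyl group matters to the activity of compound 1, which a carboxylic acid or a primary amide in its place on the same 1,2-oxazol-3-yl ring could test.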